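Swapping the Aryl Group on a Ketone Carbonyl

The compounds below may be only part of what the source reports. "The series", "measured", "known", "first", "only" and "open" are said of these compounds alone.

Measured so far:
Compound 1, `COc1ccc(C(=O)c2ccc3c(c2)C(n2ccccc2=O)=CC(C)(C)O3)cc1`: 5.72
Compound 2, `CC1(C)C=C(n2ccccc2=O)c2cc(C(=O)c3ccco3)ccc2O1`: 5.92

Both compounds were tested in a functional assay (trachea) with Rattus norvegicus as the target; on this read-out higher numbers stand for higher potency (the scale is a negative logarithm) and lower numbers for lower potency. Compound 2 holds the higher of the two numbers, but the gap is small: a number 0.20 log units higher from compound 1 to compound 2 (within the scatter). Within the usual scatter of this kind of measurement, the two compounds therefore look alike.

Compound 3, `CC1(C)C=C(n2ccccc2=O)c2cc(C(=O)c3ccccc3F)ccc2O1`, is not yet measured. It differs from compound 2 in one place: 2-fluorophenyl in place of furan-2-yl on a carbonyl carbon. Going by the values given here, this is the same kind of change as the only step measured so far, where one aromatic group on the carbonyl carbon gave way to another, and that step, a number 0.20 log units higher from compound 1 to compound 2 (within the scatter), stayed inside the scatter. Nothing in the two measured compounds points to a large move in either direction for a third aromatic group at this position.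

Compound 3 is therefore expected to give about 5.8, with a likely range from 5.3 to 6.3. The step this estimate means, a number 0.12 log units lower from compound 2 to compound 3 (within the scatter), is expected to stay within the scatter.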

Compound 3, logarithm of the reciprocal of the active concentration, log(1/C): 6.34
Compound 3: the middle estimate sits 0.54 log units below what was measured; measured number above the stated range.
By their numbers in this assay, from the lowest: compounds 1 and 2 (each within the scatter of the next); then compound 3.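

In this assay, going by these compounds alone, the group on the carbonyl carbon can move the number beyond the scatter, something the first pair of compounds did not show: the 2-fluorophenyl group gives a clear gain over furan-2-yl (a number 0.42 log units higher from compound 2 to compound 3 (beyond the scatter)) and over 4-methoxyphenyl (a number 0.62 log units higher from compound 1 to compound 3 (beyond the scatter)). Both steps are modest and both end at compound 3, which now stands apart from compound 1 and compound 2, while those two remain within the scatter of each other. No measurement shown here explains why the 2-fluorophenyl group gives the higher number.

The compounds shown leave open whether this gain belongs to the fluorine or to the six-membered aromatic ring that carries it, a question that a plain phenyl group on the carbonyl carbon would help to answer. Also open, on these data alone, is how the number would respond to a group on the carbonyl carbon that is not aromatic at all, such as a cyclohexyl group or a longer alkyl chain.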